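From phenyl to a chloropyridine on a shared core

The source may hold more compounds than are shown below. What is called first, only, known or untested is meant among the compounds shown, and "the series" means these compounds.

For the measured compounds named here, in a functional assay on MDA-MB-436 cells (Homo sapiens) for antiproliferative activity, read by MTT assay, with a stated time of 48 h (a lower number here means a stronger inhibitor, a higher number a weaker inhibitor), compound 1 (`C=CS(=O)(=O)N1CCN(c2ncnc3sc(-c4ccccc4)cc23)CC1`) gives 21100 nM and sits toward the high end of the three numbers known so far. Compound 3 (`C=CS(=O)(=O)N1CCN(c2ncnc3sc(-c4cccc5ccccc45)cc23)CC1`) gives 28100 nM and lies within the scatter of it, while compound 2 (`C=CS(=O)(=O)N1CCN(c2ncnc3sc(-c4ccc(C#N)cc4)cc23)CC1`) gives the lowest number at 9170 nM in this small set.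

Compound 4 (`C=CS(=O)(=O)N1CCN(c2ncnc3sc(-c4ccnc(Cl)c4)cc23)CC1`) is still unmeasured. It carries 2-chloropyridin-4-yl in place of phenyl on an aromatic carbon next to the ring sulfur (2-chloropyridin-4-yl in place of phenyl on an aromatic carbon). Going by the values given here, no measured step makes this exact exchange, but three steps at the same place bear on it. Adding cyano gave a modest drop (a 2.3-fold lower number from compound 1 to compound 2 (0.36 log units; beyond the scatter)), naphthalen-1-yl gave nothing beyond the scatter (a 1.3-fold higher number from compound 1 to compound 3 (0.12 log units; within the scatter)), and the widest step was still modest (a 3.1-fold higher number from compound 2 to compound 3 (0.49 log units; beyond the scatter)). A small move toward a lower number is therefore expected, one that may not clear the scatter (a 1.8-fold lower number from compound 1 to compound 4 (0.25 log units; within the scatter)). For compound 4 the estimated value is 12000 nM with 5000 nM to 28000 nM as its expected range.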

Compound 4, half-maximal inhibitory concentration: 30100 nM
Compound 4: the middle estimate sits 2.5-fold (0.40 log units) below what was measured; the measured number lies above the stated range.
By their numbers in this assay, from the lowest: compound 2; then compounds 1, 3 and 4 (each within the scatter of the next).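

In this assay, replacing phenyl with 2-chloropyridin-4-yl on this aromatic carbon gives no change beyond the scatter (a 1.4-fold higher number from compound 1 to compound 4 (0.15 log units; within the scatter)), so the lower number seen with 4-cyanophenyl does not extend to this second substituted six-membered aromatic ring. Compound 4 also cannot be told apart from the naphthalen-1-yl compound (a 1.1-fold higher number from compound 3 to compound 4 (0.03 log units; within the scatter)), so three quite different rings at this position now give numbers within the scatter of the next. Only 4-cyanophenyl stands apart from all three, and its gap to the new compound is still modest (a 3.3-fold higher number from compound 2 to compound 4 (0.52 log units; beyond the scatter)).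

Nothing here indicates why the 4-cyanophenyl and 2-chloropyridin-4-yl groups differ. On these data alone, whether an amine or a carboxylic acid on the ring at this position would give a clearly lower number remains open.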